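Amide aryl variation on the chalcone-amide series

A few compounds are considered here, and "the series" means these few. Any claim that something is new, unique, unknown or untested is made for them only; others in the source may bear on it.

Measured so far:
compound 1 `COc1ccc(C(=O)Nc2ccc(C(=O)/C=C/c3nc(C)c(C)nc3C)cc2)cc1`, 1600 nM
compound 2 `Cc1nc(C)c(/C=C/C(=O)c2ccc(NC(=O)c3ccccc3F)cc2)nc1C`, 1980 nM

In a functional assay on MDA-MB-231 cells (Homo sapiens) for antiproliferative activity, read by CCK-8 assay, with a stated time of 72 h (a lower number here means a stronger inhibitor, a higher number a weaker inhibitor), compound 1 gives 1600 nM, the lowest of the two numbers at hand, though compound 2 with 1980 nM sits within the scatter of it. Within the data shown here, the one step recorded at this position, a 1.2-fold higher number from compound 1 to compound 2 (0.09 log units; within the scatter), shows that exchanging the aryl on the carbonyl carbon has so far left the read-out essentially unchanged.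

Compound 3 `COc1cc(OC)cc(C(=O)Nc2ccc(C(=O)/C=C/c3nc(C)c(C)nc3C)cc2)c1` is not yet measured. It differs from compound 1 in one place: 3,5-dimethoxyphenyl in place of 4-methoxyphenyl on a carbonyl carbon. The step from compound 1 to compound 2 bears on it, as it also exchanges the aryl on the same carbonyl carbon, and it stayed within the scatter. Among the measured compounds shown here, no other step speaks to a second methoxy. Compound 3 is therefore expected to show no step beyond the scatter, a 1.1-fold higher number from compound 1 to compound 3 (0.05 log units; within the scatter), and its estimated value in this assay is 1800 nM with a range of 700 nM to 4500 nM.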

Compound 3, half-maximal inhibitory concentration: 11600 nM
The estimate for compound 3 lay 6.4-fold (0.81 log units) below the measured number; the measured number lies above the stated range.
By their numbers in this assay, from the lowest: compounds 1 and 2 (each within the scatter of the next); then compound 3.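

This position is not indifferent to the aryl on the carbonyl carbon: in this assay, 3,5-dimethoxyphenyl gives a 7.3-fold higher number from compound 1 to compound 3 (0.86 log units; beyond the scatter) and a 5.9-fold higher number from compound 2 to compound 3 (0.77 log units; beyond the scatter) while the earlier exchange stayed within the scatter. The change from 4-methoxyphenyl to 3,5-dimethoxyphenyl alters both the number of methoxy groups and where they sit on the ring, and the compounds shown do not separate these two changes. No measurement at hand bears on the origin of this step.

Still open, as far as these compounds go, is whether the rise in the number follows from the methoxy pattern alone or would also appear with other groups on this aryl. A phenyl carrying an amine or a carboxylic acid in place of the methoxy groups would test how far this position tolerates change.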